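Dichlorophenyl in place of isopropylphenyl on the shared core

The compounds below may be only part of what the source reports. "The series", "measured", "known", "first", "only" and "open" are said of these compounds alone.

Compound 2 `CC(=O)Nc1cccc(C2CCN(CCCn3c(-c4ccc(C(C)C)cc4)nc4ccccc43)CC2)c1` stands highest of the two numbers measured in an assay for displacement of a labelled ligand from melanin-concentrating hormone receptor 1 (Homo sapiens), read by fluorescence (on this read-out lower numbers stand for stronger inhibition and higher numbers for weaker inhibition), where compound 2 gives 60 nM. Compound 1 `CC(=O)Nc1cccc(C2CCN(CCCn3c(-c4ccccc4)nc4ccccc43)CC2)c1` carries hydrogen where compound 2 carries isopropyl. In this assay compound 1 gives 2 nM, so the step of a 30-fold higher number from compound 1 to compound 2 (1.48 log units; beyond the scatter) is large. Compound 3 `CC(=O)Nc1cccc(C2CCN(CCCn3c(-c4ccc(Cl)c(Cl)c4)nc4ccccc43)CC2)c1` arises from compound 2 through (3,4-dichlorophenyl in place of 4-isopropylphenyl on an aromatic carbon). Within the data shown here, the only step that bears on it shows that a hydrogen there does far better than isopropyl; the dichlorophenyl group with its 8 heavy atoms is a smaller group than the one it replaces, so a moderate improvement is expected, a 4.0-fold lower number from compound 2 to compound 3 (0.60 log units; beyond the scatter). For compound 3 the estimate in this assay is 15 nM, with a range from 4 nM to 60 nM.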

Compound 3, half-maximal inhibitory concentration: 24 nM
Compound 3: middle estimate off by 1.6-fold (0.20 log units), on the low side; the range from low to high includes it.
By their numbers in this assay, from the lowest: compound 1; then compound 3; then compound 2.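

In this assay, 3,4-dichlorophenyl does better than 4-isopropylphenyl on this aromatic carbon between two ring nitrogen atoms, with a 2.5-fold lower number from compound 2 to compound 3 (0.40 log units; beyond the scatter), yet it falls well short of phenyl, with a 12-fold higher number from compound 1 to compound 3 (1.08 log units; beyond the scatter). Both substituted phenyl groups shown therefore stand above compound 1, and the size of the loss differs with the group. Nothing at hand gives a reason for this difference. On these data alone, it remains open whether a phenyl with a single methoxy group, or a pyridine ring in place of the phenyl, would come close to compound 1.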